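The compounds below may be only part of what the source reports. "The series", "measured", "known", "first", "only" and "open" are said of these compounds alone.

In an ADME assay on J774.A1 cells (Mus musculus) for inhibition, read by MTT assay, with a stated time of 72 h (a higher number here means that more compound is needed for the effect, a lower number that less compound is needed), compound 2 `Cc1ccc(CNc2nc(NCc3ccccc3)c3ccccc3n2)cc1` gives 4500 nM, and compound 3 `Clc1ccc(CNc2nc(NCc3ccccc3)c3ccccc3n2)cc1` gives 3200 nM. Compound 1 `Cc1ccc(CNc2nc(NCc3ccccc3)nc3ccccc23)cc1` gives 2100 nM. Compound 2 therefore stands higher than compound 1, beyond the scatter, and level with compound 3, within it.

Compound 4 `Cc1ccc(CNc2nc(NCc3ccc(C)cc3)c3ccccc3n2)cc1` departs from compound 2 by one change, (methyl in place of hydrogen on an aromatic carbon), which is methyl in place of hydrogen on an aromatic carbon, turning benzylamino into (4-methylbenzyl)amino. For the measured compounds named here, the one measured step that bears on this is a 1.4-fold lower number from compound 2 to compound 3 (0.15 log units; within the scatter), for chloro in place of methyl on an aromatic carbon. Going by the values given here, that is a different change, and no measured step shows methyl in place of hydrogen. Among the compounds with values here, with only this small step as a guide, no shift beyond the scatter is expected in this assay. The expected step is a 1.1-fold lower number from compound 2 to compound 4 (0.05 log units; within the scatter). For compound 4 the estimated value is 4000 nM, with an expected range from 1900 nM to 8000 nM.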

Compound 4, half-maximal effective concentration: 2900 nM
Compound 4: the middle estimate sits 1.4-fold (0.14 log units) above what was measured; low and high end bracket the measured number.
By their numbers in this assay, from the lowest: compounds 1, 4, 3 and 2 (each within the scatter of the next, the first and the last beyond it).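

In this assay the change to 4-methylbenzyl now has measured steps of its own, a 1.6-fold lower number from compound 2 to compound 4 (0.19 log units; within the scatter) and a 1.4-fold higher number from compound 1 to compound 4 (0.14 log units; within the scatter), so methyl in place of hydrogen on this aromatic carbon, para to a large group, stays within the scatter from either starting compound. Compound 4 thus carries (4-methylbenzyl)amino twice and stands level with compound 1 and compound 2, even though those two lie beyond the scatter of each other. Nothing available gives a cause for these numbers.

The compounds shown leave open whether a methoxy group, a carboxylic acid or an amine on this same aromatic carbon would shift the number beyond the scatter. They also leave open what happens if a longer chain takes the place of the benzyl group.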